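Replacing a trifluoromethyl ring with a chloro analogue

The compounds below may be only part of what the source reports. "The series", "measured", "known", "first", "only" and "open" are said of these compounds alone.

Compound 1 `COc1cc(N2CCN(C(C)=O)CC2)ccc1Nc1ncc(C(F)(F)F)c(N2Cc3cccc(N(C)S(C)(=O)=O)c3C2)n1`: 3300 nM
Compound 2 `CN(c1cccc2c1CN(c1nc(Nc3ccc(Nc4ccccc4)cc3)ncc1C(F)(F)F)C2)S(C)(=O)=O`: 6200 nM
Compound 3 `CN(c1cccc2c1CN(c1nc(Nc3ccc(C(F)(F)F)cc3)ncc1C(F)(F)F)C2)S(C)(=O)=O`: > 30000 nM (a limit, not a number)

All three were tested in a functional assay on A549 cells (Homo sapiens) for antiproliferative activity, read by spectrophotometry, with a stated time of 2 days; a lower number here means a stronger inhibitor of growth, a higher number a weaker inhibitor of growth. Compounds 1 and 2 give real numbers. Compound 3 gives > 30000 nM, which is only a limit of the assay, and (the limit of > 30000 nM in this assay, at which 1 of the 3 values shown sits).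

Compound 4 `CN(c1cccc2c1CN(c1nc(Nc3cc(Cl)cc(C(F)(F)F)c3)ncc1C(F)(F)F)C2)S(C)(=O)=O` carries 3-chloro-5-(trifluoromethyl)phenyl in place of 4-(trifluoromethyl)phenyl on a nitrogen on an aromatic ring. For the measured compounds named here, one measured step bears on this group: an at least 4.8-fold higher number from compound 2 to compound 3 (0.68 log units; beyond the scatter). Going by these compounds, that step lies beyond the scatter, but it ends on a limit, so its true size is unknown. Going by the values given here, no measured step shows what adding chlorine does. Compound 4, like compound 3, lacks the anilino group that compound 2 carries at 6200 nM, so little recovery in this assay is expected. Another limit is quite possible for compound 4. The estimated step is small and towards a lower number: an at least 1.3-fold lower number from compound 3 to compound 4 (0.13 log units; that floor lies within the scatter). For compound 4 the expected value is 22000 nM, with an estimated range of 8000 nM to 50000 nM.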

Compound 4, concentration for 50% growth inhibition: 6700 nM
Beside the measured number, compound 4's estimate is 3.3-fold (0.52 log units) above it; the whole stated range lies above it.
By their numbers in this assay, from the lowest: compounds 1, 2 and 4 (each within the scatter of the next, the first and the last beyond it). At a limit, above all of these: compound 3.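

In this assay, the ring on this nitrogen matters even without an anilino group: 3-chloro-5-(trifluoromethyl)phenyl in place of 4-(trifluoromethyl)phenyl gives an at least 4.4-fold lower number from compound 3 to compound 4 (0.65 log units; beyond the scatter). Compound 3 gives > 30000 nM, a limit and not a number, so the full size of this step cannot be read: the limit of > 30000 nM in this assay, at which 1 of the 4 values shown sits. Compound 4 at 6700 nM and compound 2 at 6200 nM lie within the scatter of each other, so an anilino group is not required for a measurable value on this ring.

This single change both adds a chlorine and alters where the trifluoromethyl group sits, so the compounds shown cannot separate the two. Going by these compounds, how a plain 3-chlorophenyl ring, or a ring carrying an amine or a carboxylic acid, would behave here remains open.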